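Epimer of a Glycosylated Core Under Test

The source may hold more compounds than are shown below. What is called first, only, known or untested is meant among the compounds shown, and "the series" means these compounds.

The study measures glycosides of a common core in a functional assay on MCF7 cells (Homo sapiens) for antiproliferative activity, read by crystal violet staining, with a stated time of 96 h; on this read-out lower numbers stand for stronger inhibition and higher numbers for weaker inhibition. Compound 1, `O=C1/C(=C2/C(=O)N([C@@H]3O[C@H](CO)[C@@H](O)[C@H](O)[C@H]3O)c3ccccc32)Nc2ccccc21`, is the weaker of the two compounds already measured: in this assay compound 1 gives 15700 nM, the highest of the two numbers at hand. Compound 2, `C[C@@H]1O[C@H](N2C(=O)/C(=C3\Nc4ccccc4C3=O)c3ccccc32)[C@H](O)[C@H](O)[C@H]1O`, carries a different sugar and is not a single-point neighbour of compound 1. In this assay compound 2 gives 760 nM, a much lower number, and the gap between the two lies beyond the scatter of repeated measurements.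

Compound 3, `O=C1/C(=C2/C(=O)N([C@@H]3O[C@H](CO)[C@H](O)[C@H](O)[C@H]3O)c3ccccc32)Nc2ccccc21`, is the closest relative of compound 1 and has not yet been measured. The difference between them is confined to configuration: the two compounds have the same atoms and bonds and differ only in configuration as drawn: 1 of 6 stereo elements differ; a stereocentre at a saturated ring carbon is drawn S in compound 1 and R in compound 3. Going by the values given here, no pair of measured compounds shows a step of this kind, so nothing in the present data tells how such a change in drawn configuration at the sugar plays out.

In this assay the step from compound 1 to compound 3 is expected to be small, a 1.6-fold lower number from compound 1 to compound 3 (0.20 log units; within the scatter), most likely within the scatter, with a slight lean toward a lower number. Compound 3 is accordingly estimated at 10000 nM, with a range from 3000 nM to 40000 nM.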

Compound 3, half-maximal inhibitory concentration: 25800 nM
For compound 3 the middle estimate is 2.6-fold (0.41 log units) below the measured one; the range from low to high includes it.
By their numbers in this assay, from the lowest: compound 2; then compounds 1 and 3 (each within the scatter of the next).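

Going by these compounds alone, the step from compound 1 to compound 3 is the first in this set to isolate drawn configuration at a single saturated ring carbon of the sugar, a kind of step that no earlier pair offered. In this assay it reads a 1.6-fold higher number from compound 1 to compound 3 (0.22 log units; within the scatter), so moving this stereocentre from S to R leaves the two compounds indistinguishable in this read-out, and at this position the drawn configuration shows no effect that can be told from the scatter. The pair can be read directly as a test of this one stereocentre, with no other structural difference to weigh against it: the fact that compounds 1 and 3 differ only in the configuration as drawn

The compounds shown leave open whether the other stereo elements of the sugar would be as silent in this assay, and what accounts for the value of compound 2, which carries a different sugar and is not a single-place neighbour of either compound 1 or compound 3. They also do not tell how a sugar bearing an amine or a carboxylic acid would behave on the same core.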